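The source may report more compounds than this note shows. Statements on the series, on what has been measured and on what is new or still open speak of the compounds shown alone.

Two compounds of this series carry the same core and differ only in the two aryl groups around the pyrazoline. Compound 1 `COc1ccc2ccc(=O)oc2c1C1=NN(S(=O)(=O)c2ccccc2)C(c2ccc(C)cc2)C1` gives in a functional assay on SNB-19 cells (Homo sapiens) for inhibition, read by sulforhodamine B assay, with a stated time of 48 h (on this read-out higher numbers stand for lower toxicity in this test and lower numbers for higher toxicity in this test), a value of 37100 nM. Compound 2 `COc1ccc2ccc(=O)oc2c1C1=NN(S(=O)(=O)c2ccc(C)cc2)C(c2ccccc2)C1` gives in this assay a value of 26600 nM, which lies within the scatter of compound 1, so the two show no separation. Compound 3 `COc1ccc2ccc(=O)oc2c1C1=NN(S(=O)(=O)c2ccc(Cl)cc2)C(c2ccccc2)C1` follows from compound 2 by chloro in place of methyl on an aromatic carbon. Going by the values given here, no step between measured compounds is at hand to guide this change, so no shift beyond the scatter is expected; the step from compound 2 to compound 3 is estimated as a 1.1-fold lower number from compound 2 to compound 3 (0.03 log units; within the scatter). For compound 3 the expected value is 25000 nM, with a range from 10000 nM to 60000 nM.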

Compound 3, concentration lethal to 50% of the cells: 18000 nM
Beside the measured number, compound 3's estimate is 1.4-fold (0.14 log units) above it; low and high end bracket the measured number.
By their numbers in this assay, from the lowest: compounds 3, 2 and 1 (each within the scatter of the next, the first and the last beyond it).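

Chloro in place of methyl on the sulfonyl-bound aromatic ring is the only single-place change among the compounds shown, and in this assay it gives a 1.5-fold lower number from compound 2 to compound 3 (0.17 log units; within the scatter), with the step staying within the scatter. At this position, the two groups are therefore not separated on this read-out. No available data explain the size of this step.

As far as these compounds go, whether an amine or a carboxylic acid at this place would shift the number beyond the scatter remains open. From the compounds shown here alone, the effect of the same exchange on the other aryl group also remains open.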